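Chloro on the aryl ring of a prenyloxy coumarin pyrazole

This account rests on a few compounds, and the source may have more. Where it says the series, first, only, none or still open, it means among the compounds named here.

Compound 1 `CCOC(=O)c1c(-c2cc3ccccc3oc2=O)nn(-c2cccc(Cl)c2)c1C(=O)OCC`: 28000 nM in a functional assay on A549 cells (Homo sapiens) for cytotoxicity, read by MTT assay, with a stated time of 48 h; on this read-out lower numbers stand for stronger inhibition and higher numbers for weaker inhibition
Compound 2 `CCOC(=O)c1c(-c2cc3ccc(OC)cc3oc2=O)nn(-c2ccccc2)c1C(=O)OCC`: 132000 nM in this assay
Compound 3 `CCOC(=O)c1c(-c2cc3ccc(OCC=C(C)C)cc3oc2=O)nn(-c2ccccc2)c1C(=O)OCC`: 136000 nM in this assay

Compound 3 gives the highest of the three numbers; compound 2 lies within the scatter of it, and compound 1 is the furthest away. Among the measured compounds shown here, the only single-site comparison, a 1.0-fold higher number from compound 2 to compound 3 (0.01 log units; within the scatter), shows that lengthening the ether chain changes nothing beyond the scatter. Compound 4 `CCOC(=O)c1c(-c2cc3ccc(OCC=C(C)C)cc3oc2=O)nn(-c2cccc(Cl)c2)c1C(=O)OCC` differs from compound 3 by chloro in place of hydrogen on an aromatic carbon. For the measured compounds named here, no measured pair isolates this change. Compound 1, at 28000 nM, does sit well below compound 3, at 136000 nM, but the two also differ on the coumarin ring, so only part of that gap may be ascribed to the chloro. Compound 4 is therefore expected near 50000 nM, within 15000 nM to 160000 nM, an expected step of a 2.7-fold lower number from compound 3 to compound 4 (0.43 log units; beyond the scatter) toward a lower number.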

Compound 4, half-maximal inhibitory concentration: 163000 nM
For compound 4 the middle estimate is 3.3-fold (0.51 log units) below the measured one; the whole stated range lies below it.
By their numbers in this assay, from the lowest: compound 1; then compounds 2, 3 and 4 (each within the scatter of the next).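

In this assay, the change from phenyl to 3-chlorophenyl gives a 1.2-fold higher number from compound 3 to compound 4 (0.08 log units; within the scatter) and so does not move the number beyond the scatter when the (3-methylbut-2-en-1-yl)oxy group is present. Among the compounds shown here, with the 3-chlorophenyl group held fixed, adding that ether gives a 5.8-fold higher number from compound 1 to compound 4 (0.77 log units; beyond the scatter) as the first single-site step beyond the scatter, so chloro alone does not account for the low number of compound 1. Going by these compounds, it remains open whether an amine or a carboxylic acid on this aromatic carbon would shift the number, and whether chloro matters without the ether. Nothing available explains these numbers.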